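Fluoro in Place of Methoxy and Cytotoxicity Across Two Cores

The source may hold more compounds than are shown below. What is called first, only, known or untested is meant among the compounds shown, and "the series" means these compounds.

Compound 1 `COc1ccccc1/C=C/C(=O)c1cc(NC(C)=O)ccc1O` and compound 2 `CC(=O)Nc1ccc(O)c(C(=O)/C=C/c2ccccc2F)c1` share one core. In an ADME assay on THP-1 cells (Homo sapiens) for cytotoxicity, read by flow cytometry and propidium iodide staining, with a stated time of 72 h (a higher number here means a weaker inhibitor, a lower number a stronger inhibitor), compound 1 gives > 125000 nM, which is a limit of the assay and not a number. Compound 2 gives > 125000 nM in this assay, again a limit. The change between them, (fluoro in place of methoxy on an aromatic carbon), thus gives a step that the two limits leave unreadable from compound 1 to compound 2, since both values sit at the limit of > 125000 nM in this assay, at which 2 of the 3 values shown sit.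

Compound 3 `COc1ccccc1-c1cc(=O)c2cc(N)ccc2o1` has a different core; how it differs from compound 1 is not broken down here. In this assay, among the compounds with values here, compound 3 gives 74000 nM, the only number among the three measured values. Compound 4 `Nc1ccc2oc(-c3ccccc3F)cc(=O)c2c1` differs from compound 3 by fluoro in place of methoxy on an aromatic carbon, the same change as between compound 1 and compound 2. Because that earlier change gave a step that the two limits leave unreadable from compound 1 to compound 2, it offers no readable guide, so the expectation for compound 4 rests on the value of compound 3, 74000 nM, alone. The step of no change at the digits printed from compound 3 to compound 4 (within the scatter) is estimated to be small. Compound 4 is therefore expected to give about 74000 nM in this assay, within 30000 nM and 150000 nM.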

Compound 4, half-maximal inhibitory concentration: 44000 nM
For compound 4 the middle estimate is 1.7-fold (0.23 log units) above the measured one; the measured number falls inside the stated range.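

In this assay, fluoro in place of methoxy on an aromatic carbon gives a 1.7-fold lower number from compound 3 to compound 4 (0.23 log units; within the scatter), so on the core of compound 3 the two values cannot be told apart and the change shows no readable effect. On the core of compound 1 the same change cannot be read at all, because compound 1 and compound 2 each give a limit of the assay and not a number: the limit of > 125000 nM in this assay, at which 2 of the 4 values shown sit. The series therefore holds a single readable instance of this change, which does not show that the result carries from one core to the other, only that nothing on the second core goes against it.

The compounds shown leave open how a group other than methoxy or fluoro, such as chloro, an amine or a carboxylic acid, would read at this aromatic carbon on either core in this assay. They also leave open whether any such group would bring the core of compound 1 to a readable number.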